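Swapping Cyclohexyl for Phenethyl at the Sulfonamide Nitrogen

The compounds below may be only part of what the source reports. "The series", "measured", "known", "first", "only" and "open" are said of these compounds alone.

Measured compounds:
- compound 1, `COc1ccc(CN2c3ccccc3C(=O)N(Cc3ccccc3)S2(=O)=O)cc1`: 61000 nM
- compound 2, `O=C1c2ccccc2N(Cc2ccc(C(F)(F)F)cc2)S(=O)(=O)N1Cc1ccccc1`: 56000 nM
- compound 3, `O=C1c2ccccc2N(CC2CCCCC2)S(=O)(=O)N1Cc1ccccc1`: > 65000 nM

All three share one core and differ only in the group on the saturated chain carbon bound to the sulfonamide nitrogen in the ring. In a functional assay on MRC5 cells (Homo sapiens) (on this read-out lower numbers stand for higher toxicity in this test and higher numbers for lower toxicity in this test), compound 1 gives 61000 nM. In this assay compound 2 gives 56000 nM. For compound 3 this assay reports no number, only the limit > 65000 nM. Compound 3 therefore sits at the limit of > 65000 nM in this assay, at which 1 of the 3 values shown sits, and not at a measured point.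

The steps among these three are small: a 1.1-fold lower number from compound 1 to compound 2 (0.04 log units; within the scatter), an at least 1.0-fold higher number from compound 1 to compound 3 (0.02 log units; that floor lies within the scatter), and an at least 1.1-fold higher number from compound 2 to compound 3 (0.06 log units; that floor lies within the scatter). None of them rises above the scatter, so the three variants at this position look alike in this test.

Compound 4, `O=C1c2ccccc2N(CCCc2ccccc2)S(=O)(=O)N1Cc1ccccc1`, has not yet been measured. It differs from compound 3 by phenethyl in place of cyclohexyl on a saturated chain carbon bound to a sulfonamide nitrogen in a ring. Since every measured change at this position stayed within the scatter, no step beyond the scatter is expected here either, and the value of compound 4 is estimated at 60000 nM, with a range from 30000 nM to 130000 nM. This estimate means an expected step of an at least 1.0-fold lower number from compound 3 to compound 4 (0.03 log units; that floor lies within the scatter). The chance that this assay again reports only a limit for compound 4 is substantial.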

Compound 4, half-maximal cytotoxic concentration: > 57000 nM
Compound 4 gave a limit, no number (the forecaster's own chance of this, stated with the estimate: 50%); the middle value is on the limit's open side.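

In this assay compound 4 gives only a limit, not a number: the limit of > 57000 nM in this assay, at which 1 of the 4 values shown sits.

The earlier compounds shown here varied the group on the chain carbon, while this change also lengthens the link to the ring: cyclohexylmethyl becomes 3-phenylpropyl, and the aromatic ring of phenethyl replaces the non-aromatic ring of cyclohexyl. Even so, the one step that can be read is an at least 1.0-fold higher number from compound 2 to compound 4 (0.00 log units; that floor lies within the scatter), so this longer chain gives no sign of a lower number in this test, and the steps to compound 4 from compound 1 and compound 3 cannot be read.

As far as these compounds go, how far compound 3 and compound 4 truly lie from each other stays open, since neither has a measured value in this assay, and a limit only marks where the test stopped giving a number. Also open is whether any group at this position can bring the number down clearly, for example an amine or a carboxylic acid at the end of the chain, since every variant shown here stays within the scatter of the others wherever a step can be read.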